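The compounds below may be only part of what the source reports. "The series", "measured", "known", "first", "only" and "open" are said of these compounds alone.

Measured so far in a functional assay, read by spectrophotometry, with a stated time of 30 min; on this read-out lower numbers stand for stronger inhibition and higher numbers for weaker inhibition:
compound 1 `Cc1nc2c3ccccc3ccc2c2nc3c(ccc4ccccc43)c(-c3cccc([N+](=O)[O-])c3)c12`, 117 ug/mL
compound 2 `COc1ccc(-c2c3ccc4ccccc4c3nc3c2c(C)nc2c4ccccc4ccc32)cc1`, 133 ug/mL
compound 3 `Cc1nc2c3ccccc3ccc2c2nc3c(ccc4ccccc43)c(-c3ccccc3N)c12`, 95.4 ug/mL

Compound 3 sits at the smaller end of the three numbers in this assay, but the steps of a 1.2-fold lower number from compound 1 to compound 3 (0.09 log units; within the scatter) and a 1.4-fold lower number from compound 2 to compound 3 (0.14 log units; within the scatter) are both within the scatter, and a 1.1-fold higher number from compound 1 to compound 2 (0.06 log units; within the scatter) is as well, so the three compounds are not separated from one another on these data.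

Compound 4 `Cc1nc2c3ccccc3ccc2c2nc3c(ccc4ccccc43)c(-c3ccc(O)cc3)c12` differs from compound 3 in one place: 4-hydroxyphenyl in place of 2-aminophenyl on an aromatic carbon. Within the data shown here, the steps that bear on this change are those where the group on the same aromatic carbon of the shared core was varied, a 1.4-fold lower number from compound 2 to compound 3 (0.14 log units; within the scatter) and a 1.2-fold lower number from compound 1 to compound 3 (0.09 log units; within the scatter), and neither moved the number beyond the scatter. Three different substituents on that carbon gave numbers of the same size, so a fourth is expected to do the same: the step of a 1.2-fold higher number from compound 3 to compound 4 (0.06 log units; within the scatter) is expected to lie within the scatter, with no direction claimed. Compound 4 is therefore estimated at 110 ug/mL, with a range from 60 ug/mL to 200 ug/mL.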

Compound 4, half-maximal inhibitory concentration: 86.4 ug/mL
Compound 4: middle estimate off by 1.3-fold (0.10 log units), on the high side, and the stated range covers the measured number.
By their numbers in this assay, from the lowest: compounds 4, 3, 1 and 2 (each within the scatter of the next).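

In this assay, the group on this aromatic carbon, opposite the ring nitrogen, now extends to a fourth substituent without separating from the others: neither a 1.1-fold lower number from compound 3 to compound 4 (0.04 log units; within the scatter) nor a 1.4-fold lower number from compound 1 to compound 4 (0.13 log units; within the scatter) leaves the scatter. Among these compounds, the step of a 1.5-fold lower number from compound 2 to compound 4 (0.19 log units; within the scatter) is the first to alter only the oxygen on the aromatic ring, with hydrogen in place of methyl, and it too stays within the scatter, so this change has no resolved effect on the read-out. No supporting data bear on these results.

On these data alone, all four compounds carry a substituted phenyl ring on this carbon, so the effect of a carboxylic acid on that ring, or of a saturated amine such as morpholine in its place, remains open. As far as these compounds go, whether a longer chain in place of the methyl on the shared core would move the number beyond the scatter also remains open.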